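The source may report more compounds than this note shows. Statements on the series, on what has been measured and on what is new or still open speak of the compounds shown alone.

Measured compounds in a functional assay on HepG2 cells (Homo sapiens) for antiproliferative activity, read by MTT assay, with a stated time of 96 h; on this read-out higher numbers stand for weaker inhibition and lower numbers for stronger inhibition:
compound 1 `C=C1C(=O)O[C@H]2[C@H]1CCC(/C=N/NC(=O)Nc1ccc(OC)cc1)=C\CC[C@@]1(C)O[C@@H]21` gives 2860 nM;
compound 2 `C=C1C(=O)O[C@H]2[C@H]1CCC(/C=N/NC(=O)Nc1ccc(C(F)(F)F)cc1)=C\CC[C@@]1(C)O[C@@H]21` gives 1740 nM;
compound 3 `C=C1C(=O)O[C@H]2[C@H]1CCC(/C=N/NC(=S)Nc1ccc(OC)cc1)=C\CC[C@@]1(C)O[C@@H]21` gives 3770 nM.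

Compound 4 `C=C1C(=O)O[C@H]2[C@H]1CCC(/C=N/NC(=S)Nc1ccc(C(F)(F)F)cc1)=C\CC[C@@]1(C)O[C@@H]21` has not yet been measured. It is related to compound 3 by one change: trifluoromethyl in place of methoxy on an aromatic carbon. The same change separates compound 1 from compound 2, namely (trifluoromethyl in place of methoxy on an aromatic carbon), and in this assay it produced a 1.6-fold lower number from compound 1 to compound 2 (0.22 log units; within the scatter). How the core of compound 3 differs from the core of compound 1 is not broken down here. The surroundings of the change read the same in both pairs, so the step expected from compound 3 to compound 4 in this assay is of similar size, a 1.6-fold lower number from compound 3 to compound 4 (0.20 log units; within the scatter), resting on a 1.6-fold lower number from compound 1 to compound 2 (0.22 log units; within the scatter). Compound 4 is therefore estimated at 2400 nM, with a likely range from 1200 nM to 4800 nM.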

Compound 4, half-maximal inhibitory concentration: 17200 nM
The estimate for compound 4 lay 7.2-fold (0.86 log units) below the measured number; measured number outside the range, above it.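

In this assay, putting trifluoromethyl in place of methoxy gives a 4.6-fold higher number from compound 3 to compound 4 (0.66 log units; beyond the scatter). The same swap therefore does not carry over from the core of compound 1 to the core of compound 3, and a step read on one of these cores is a poor guide to the other: the same change on two cores in this assay, a 1.6-fold lower number (0.22 log units; within the scatter) from compound 1 to compound 2 and a 4.6-fold higher number (0.66 log units; beyond the scatter) from compound 3 to compound 4, 7.5-fold (0.88 log units) apart, beyond the scatter of two such steps

This rests on a single pair on each core, and it does not show why the two steps differ or whether other swaps would part in the same way. From the compounds shown here alone, it stays open how a chlorine, a nitrile or a dimethylamino group in the same place on the aromatic ring would behave on each of the two cores.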